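Swapping the ring on the ester-bearing carbon

This account rests on a few compounds, and the source may have more. Where it says the series, first, only, none or still open, it means among the compounds named here.

The measured compounds:
compound 1 `C=C(C(=O)c1ccc(OC)cc1)C(OC(=O)c1ccccc1)c1ccccc1F`, 14300 nM
compound 2 `C=C(C(=O)c1ccc(OC)cc1)C(OC(=O)c1ccccc1)c1ccc(Cl)cc1Cl`, 9700 nM
compound 3 `C=C(C(=O)c1ccc(OC)cc1)C(OC(=O)c1ccccc1)C1CCCCC1`, 10000 nM

In a functional assay on NB-4 cells (Homo sapiens) for inhibition, read by XTT assay, with a stated time of 48 h (on this read-out higher numbers stand for weaker inhibition and lower numbers for stronger inhibition), compound 3 stands second highest of the three numbers, with compound 2 nearest and compound 1 furthest, both within the scatter. The step to compound 4 `C=C(C(=O)c1ccc(OC)cc1)C(OC(=O)c1ccccc1)c1ccc([N+](=O)[O-])cc1` is 4-nitrophenyl in place of cyclohexyl on a saturated chain carbon bound to a double-bonded chain carbon and an oxygen next to a carbonyl group. The earlier swaps at this same carbon, a 1.5-fold lower number from compound 1 to compound 2 (0.17 log units; within the scatter), a 1.4-fold lower number from compound 1 to compound 3 (0.16 log units; within the scatter) and a 1.0-fold higher number from compound 2 to compound 3 (0.01 log units; within the scatter), all stayed within the scatter, so the group at this position has so far not moved the number. The 4-nitrophenyl ring is a new kind of group here, yet nothing in the data points to a shift, and no step beyond the scatter is expected, no change at the digits printed from compound 3 to compound 4 (within the scatter). Compound 4 is estimated at 10000 nM, ranging from 4000 nM to 30000 nM.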

Compound 4, half-maximal inhibitory concentration: 13200 nM
Compound 4: the middle estimate sits 1.3-fold (0.12 log units) below what was measured; the range from low to high includes it.
By their numbers in this assay, from the lowest: compounds 2, 3, 4 and 1 (each within the scatter of the next).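

In this assay, among these compounds, the 4-nitrophenyl ring puts nitrogen, oxygen and hydrogen-bond acceptors on this carbon for the first time, yet the steps are a 1.3-fold higher number from compound 3 to compound 4 (0.12 log units; within the scatter) and a 1.4-fold higher number from compound 2 to compound 4 (0.13 log units; within the scatter) and a 1.1-fold lower number from compound 1 to compound 4 (0.03 log units; within the scatter) and none of them leaves the scatter. Across these four compounds, then, neither an aromatic ring in place of cyclohexyl nor a group with acceptors separates one compound from another.

Still open, on these data alone, is whether an amine, a carboxylic acid or a longer chain at this carbon would move the number beyond the scatter. No measurement at hand says why this position has shown so little response.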